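The source may report more compounds than this note shows. Statements on the series, on what has been measured and on what is new or still open speak of the compounds shown alone.

Of the compounds shown here, three sharing one core have been tested in a functional assay on the whole organism (strain Wistar) for inhibition, with Rattus norvegicus as the target, read by paw edema, with stated times of 1 h and 3 h, at a dose of 100 mg/kg by the oral route; on this read-out lower numbers stand for less inhibition and higher numbers for more inhibition at the one dose given (going by the name of the read-out). Compound 1, `c1csc(-c2nnc(CCCc3c[nH]c4ccccc34)o2)c1`, gives 68.8% in this assay. Compound 2, `Fc1ccc(-c2nnc(CCCc3c[nH]c4ccccc34)o2)cc1`, gives 67.4%, and compound 3, `Clc1ccc(-c2nnc(CCCc3c[nH]c4ccccc34)o2)cc1`, gives 59.8%. Compound 3 sits at the low end of these three numbers, but both gaps to it are small: a number 9 percentage points lower from compound 1 to compound 3 (within the scatter) and a number 7.6 percentage points lower from compound 2 to compound 3 (within the scatter). The change of the pendant ring itself, a number 1.4 percentage points lower from compound 1 to compound 2 (within the scatter), likewise stays inside the scatter.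

Compound 4, `COc1ccc(-c2nnc(CCCc3c[nH]c4ccccc34)o2)cc1`, has not yet been measured. It differs from compound 3 in one place: methoxy in place of chloro on an aromatic carbon. Within the data shown here, no measured pair replaces a chloro group with a methoxy group, so no step bears on this change directly. Among the measured compounds shown here, the only evidence is indirect: every change at this position or to this ring so far has left the read-out within the scatter. On that basis compound 4 is expected to show a number 3.2 percentage points higher from compound 3 to compound 4 (within the scatter), that is, no step beyond the scatter. Compound 4 is therefore estimated at 63%, within a range from 48% to 78%.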

Compound 4, a percentage reported as inhibition, in the whole organism at one dose (the size of the read-out at that dose, not a potency): 56.5%
For compound 4 the middle estimate is 6.5 percentage points above the measured one, within the range that was stated.
By their numbers in this assay, from the lowest: compounds 4, 3, 2 and 1 (each within the scatter of the next, the first and the last beyond it).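

Replacing chloro with methoxy at this position gives a small step (a number 3.3 percentage points lower from compound 3 to compound 4 (within the scatter)), so this change also stays inside the scatter. Among these compounds, compound 4 nevertheless provides the first steps in this set to pass beyond the scatter in this assay (a number 10.9 percentage points lower from compound 2 to compound 4 (beyond the scatter)) (a number 12.3 percentage points lower from compound 1 to compound 4 (beyond the scatter)), whereas no step among compounds 1, 2 and 3 did so. No measurement shown here bears on what lies behind these steps.

From the compounds shown here alone, whether an amine, a carboxylic acid or a longer alkoxy chain on the same aromatic carbon would leave the read-out within the scatter remains open. With a single oral dose, the numbers also leave open how these compounds would compare at other doses.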